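The source may report more compounds than this note shows. Statements on the series, on what has been measured and on what is new or still open speak of the compounds shown alone.

Three compounds with the shared core of compound 1, `O=C1NC(=S)S/C1=C\C=C\c1ccccc1OS(=O)(=O)c1ccccc1`, were examined in a functional assay on DLD-1 cells (Homo sapiens), read by microscopy and crystal violet staining, with a stated time of 20 h, tested at 10 ug/mL (a lower number here means less inhibition, a higher number more inhibition at the concentration tested (going by the name of the read-out)), where compound 1 gives 80%. Compound 2, `COc1cccc(COc2ccccc2/C=C/C=C2\SC(=S)NC2=O)c1`, gives 82% in this assay, the second highest of the three numbers; its nearest neighbour is compound 1, a number only slightly lower and within the scatter, so no order between the two can be claimed. Compound 3, `O=C1NC(=S)S/C1=C\c1cc(Br)ccc1OCc1ccccc1Br`, gives 95% in this assay, a number that stands above compound 2 by a margin beyond the scatter.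

Compound 4, `O=C1NC(=S)S/C1=C\C=C\c1ccccc1OCc1ccccc1Br`, has not yet been measured. It differs from compound 2 in one place: 2-bromophenyl in place of 3-methoxyphenyl on a saturated chain carbon bound to an oxygen on an aromatic ring. Within the data shown here, the same 2-bromophenyl group is present in compound 3, though compound 3 differs from compound 4 in other places as well, so no single-place step to it is available. Because compound 3 gives 95%, the step of a number 6 percentage points higher from compound 2 to compound 4 (within the scatter) is expected to be upward but modest, likely within the scatter. Compound 4 is therefore expected to give about 88% in this assay, within a range from 76% to 97%.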

Compound 4, a percentage reported as inhibition, at one concentration (the size of the read-out at that concentration, not a potency): 78%
Compound 4: the middle estimate sits 10 percentage points above what was measured; the range from low to high includes it.
By their numbers in this assay, from the lowest: compounds 4, 1 and 2 (each within the scatter of the next); then compound 3.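

On a saturated chain carbon bound to an oxygen on an aromatic ring, 2-bromophenyl in place of 3-methoxyphenyl gives, in this assay, a number 4 percentage points lower from compound 2 to compound 4 (within the scatter), so the two groups cannot be told apart at this place. This is the only single-place step among the compounds shown, and so the only direct reading of this position; it shows that the change from one substituted phenyl ring to the other, with the loss of the methoxy oxygen, leaves no difference that can be claimed. Nothing at hand explains this result. Going by these compounds, whether the number holds with something other than a substituted phenyl ring at this place stays open, for instance an amine or a carboxylic acid in its place. On these data alone, since each number comes from one concentration, it also stays open whether compound 2 and compound 4 would differ in potency.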